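The source may hold more compounds than are shown below. What is called first, only, known or untested is meant among the compounds shown, and "the series" means these compounds.

Of the compounds shown here, three have been measured in an assay on brain with Translocator protein (Rattus norvegicus) as the target; a higher number here means a weaker inhibitor, a lower number a stronger inhibitor. Compound 1 `CCOC(=O)c1c(N(CC)Cc2ccccc2)nc2ccccc2c1-c1ccccc1` gives 540 nM. Compound 2 `CCN(Cc1ccccc1)Cc1nc2ccccc2c(-c2ccccc2)c1C(=O)NCc1ccccc1` gives 2900 nM, which places it second highest of the three numbers: compound 1 sits below it beyond the usual scatter, while compound 3 `CCN(Cc1ccccc1)Cc1ccccc1C(=O)N(CC)CC`, which gives 8210 nM, sits above it, also beyond the scatter. No pair among these three differs in a single place, so none of the gaps can be tied to one change.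

Compound 4 `CCN(Cc1ccccc1)Cc1nc2ccccc2c(-c2ccccc2)c1C(=O)N(C)c1ccccc1` has not been measured in this assay. It differs from compound 2 in one place:

methyl(phenyl)amino in place of benzylamino on a carbonyl carbon

Compound 1, with its lower number, shows that a carbonyl substituent without a hydrogen-bond donor is tolerated on this core, so the step from compound 2 to compound 4 is expected to move the number downward by a moderate amount, a 2.4-fold lower number from compound 2 to compound 4 (0.38 log units; beyond the scatter), though the evidence is thin and a result within the scatter would not surprise. Compound 4 is therefore expected to give about 1200 nM in this assay, most likely between 350 nM and 4500 nM.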

Compound 4, half-maximal inhibitory concentration: 1320 nM
Estimate against measurement, compound 4: 1.1-fold (0.04 log units) below; measured number inside the range.
By their numbers in this assay, from the lowest: compound 1; then compound 4; then compound 2; then compound 3.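

In this assay, among these compounds, this is the first pair differing in one place, so a gap can now be tied to a single change on the carbonyl carbon: replacing benzylamino with methyl(phenyl)amino gives a 2.2-fold lower number from compound 2 to compound 4 (0.34 log units; beyond the scatter). The two groups have the same heavy atoms and each holds one carbon-only aromatic ring, so this modest step beyond the scatter comes from a different joining of those atoms, which also removes the amide hydrogen. Nothing measured here gives a reason for the step.

The compounds shown leave open whether the methyl on the nitrogen, the phenyl joined directly to it, or the loss of the amide hydrogen carries the step. Phenylamino and methyl(benzyl)amino on the same carbonyl carbon would separate these, and a morpholine amide would test a different kind of group there.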